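Widening the Ether Branch: From Isopropyl to Pentan-3-yl

A few compounds are considered here, and "the series" means these few. Any claim that something is new, unique, unknown or untested is made for them only; others in the source may bear on it.

Among the compounds with values here, compound 3 `CC(C)COc1cccc(O)c1C(=O)/C=C/c1ccc(O)cc1` is the only compound here with a number rather than a limit in a functional assay on NCI-H23 cells (Homo sapiens) for antiproliferative activity, read by sulforhodamine B assay (on this read-out higher numbers stand for weaker inhibition of growth and lower numbers for stronger inhibition of growth), where compound 3 gives 3220 nM. Compound 1 `CC(C)=CCOc1cccc(O)c1C(=O)/C=C/c1ccc(O)cc1` gives > 30000 nM, which is a limit of the assay. Compound 2 `O=C(/C=C/c1ccc(O)cc1)c1c(O)cccc1OCCC1CCCCC1` gives > 30000 nM, likewise a limit. Because two of the three values sit at the limit of > 30000 nM in this assay, at which 2 of the 3 values shown sit, the step that the two limits leave unreadable from compound 1 to compound 2 cannot be sized, whereas the steps of an at least 9.3-fold lower number from compound 1 to compound 3 (0.96 log units; beyond the scatter) and an at least 9.3-fold lower number from compound 2 to compound 3 (0.96 log units; beyond the scatter) are both at least modest.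

Compound 4 `CCC(CC)COc1cccc(O)c1C(=O)/C=C/c1ccc(O)cc1` differs from compound 3 by pentan-3-yl in place of isopropyl on a saturated chain carbon bound to an oxygen on an aromatic ring. The two readable steps both bear on this change: each replaces a larger group on that saturated chain carbon with isopropyl and lowers the number markedly. Pentan-3-yl moves back toward a larger group, so compound 4 is expected to show a higher number, though with a smaller change than those steps, since pentan-3-yl stays saturated and carries no ring. The author therefore estimates a 2.8-fold higher number from compound 3 to compound 4 (0.45 log units; beyond the scatter) for compound 4. Compound 4 is estimated at 9000 nM, within a range of 3000 nM to 30000 nM.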

Compound 4, concentration for 50% growth inhibition: 3210 nM
Estimate against measurement, compound 4: 2.8-fold (0.45 log units) above; the range from low to high includes it.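

At the saturated chain carbon bound to an oxygen on an aromatic ring, widening the branch leaves the read-out of this assay unchanged: the step is a 1.0-fold lower number from compound 3 to compound 4 (0.00 log units; within the scatter). The earlier compounds shown here could have suggested that any group larger than isopropyl raises the number, but compound 4 shows that carbon added to a saturated, ring-free branch does not do so by itself. Compound 4 also stands clear of the other two ethers, with an at least 9.3-fold lower number from compound 2 to compound 4 (0.97 log units; beyond the scatter) and an at least 9.3-fold lower number from compound 1 to compound 4 (0.97 log units; beyond the scatter), and these two steps are only bounds, because each starts from a limit: the limit of > 30000 nM in this assay, at which 2 of the 4 values shown sit.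

The compounds shown leave open where, between pentan-3-yl and cyclohexylmethyl, the number starts to rise. They also leave open whether an unbranched hexyl chain, or a chain ending in an amine, would hold the number at this place.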